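This account rests on a few compounds, and the source may have more. Where it says the series, first, only, none or still open, it means among the compounds named here.

Of the compounds shown here, three built on a shared core have been tested in a functional assay on the whole organism (aorta) with Rattus norvegicus as the target; a higher number here means a larger maximal response, a lower number a smaller maximal response. Compound 1, with the structure `CC1(C)C=C(n2ccccc2=O)c2cc(S(=O)(=O)N=[N+]=[N-])ccc2O1`, gives 88.3%, the highest of the three numbers. Compound 2, `COc1ccc(NS(=O)(=O)c2ccc3c(c2)C(n2ccccc2=O)=CC(C)(C)O3)cc1`, gives 77.9%, and compound 3, `CC1(C)C=C(n2ccccc2=O)c2cc(S(=O)(=O)Nc3ccc(C#N)cc3)ccc2O1`, gives 84%. The step of a number 10.4 percentage points lower from compound 1 to compound 2 (beyond the scatter) is the only one beyond the scatter, while a number 4.3 percentage points lower from compound 1 to compound 3 (within the scatter) and a number 6.1 percentage points higher from compound 2 to compound 3 (within the scatter) both stay within it. Each of the two measured steps away from compound 1 puts an (4-methoxyphenyl)amino or (4-cyanophenyl)amino group in place of the azido group on the sulfonyl sulfur; one is a modest decrease and the other stays within the scatter.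

Compound 4, `CC1(C)C=C(n2ccccc2=O)c2cc(S(=O)(=O)c3ccccc3)ccc2O1`, has not yet been measured in this assay. It differs from compound 1 by phenyl in place of azido on a sulfonyl sulfur. Among the measured compounds shown here, the azido group is again replaced, this time by phenyl on the sulfonyl sulfur, and no measured step covers this exact change. The steps of a number 10.4 percentage points lower from compound 1 to compound 2 (beyond the scatter) and a number 4.3 percentage points lower from compound 1 to compound 3 (within the scatter) indicate that losing the azido group costs little or nothing beyond the scatter, so at most a small drop is expected. For compound 4 the estimate is 82%, in the range 70% to 93%. This corresponds to an expected step of a number 6.3 percentage points lower from compound 1 to compound 4 (within the scatter).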

Compound 4, largest response reached (Emax), in percent of the reference or control that the assay uses: 79.3%
Estimate against measurement, compound 4: 2.7 percentage points above; measured number inside the range.
By their numbers in this assay, from the lowest: compounds 2, 4, 3 and 1 (each within the scatter of the next, the first and the last beyond it).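

In this assay the step of a number 9 percentage points lower from compound 1 to compound 4 (within the scatter) shows that the azido group can give way to a plain phenyl ring attached directly to the sulfonyl sulfur, so the amino link present in compounds 2 and 3 is not needed to keep the response within the scatter of compound 1. The steps of a number 4.7 percentage points lower from compound 3 to compound 4 (within the scatter) and a number 1.4 percentage points higher from compound 2 to compound 4 (within the scatter) add that dropping this amino link together with the cyano or methoxy group leaves compound 4 within the scatter of both anilide-type compounds, which means that it cannot be told apart from any of the other three. Among the compounds shown here, the only pair still separated beyond the scatter is compound 1 and compound 2, and nothing available here explains why these groups behave so alike.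

The compounds shown leave open whether a small methyl group or a simple unsubstituted amino group on the sulfonyl sulfur would keep the response in this same range. As far as these compounds go, it also remains open whether a phenyl ring carrying a carboxylic acid would do so.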